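The source may report more compounds than this note shows. Statements on the series, on what has been measured and on what is new or still open speak of the compounds shown alone.

Compound 1, `COc1ccc(Cl)cc1S(=O)(=O)Nc1ccc(-c2nc3ccccc3o2)cc1`: > 63000 nM
Compound 2, `O=S(=O)(Nc1ccc(-c2nc3ccccc3o2)cc1)c1ccc(Cl)s1`: > 63000 nM
Compound 3, `O=S(=O)(Nc1ccc2oc(-c3ccccc3)nc2c1)c1ccc(O)cc1`: > 63000 nM

All three compounds were measured in an assay on isolated protein for inhibition of malate dehydrogenase, mitochondrial (Sus scrofa), with stated times of 45 min and 30 min (a lower number here means a stronger inhibitor, a higher number a weaker inhibitor), and each returned only a limit of the assay rather than a number. For compound 1 the result is the limit > 63000 nM. For compound 2 the result is again a limit, > 63000 nM. Compound 3 likewise stands at the limit > 63000 nM, so its true value is not known beyond the fact that it lies outside what the assay reports. Among the compounds with values here, the one step between measured compounds that differ in a single place, a step that the two limits leave unreadable from compound 1 to compound 2, cannot be read at all, since both of its ends are limits. Within the data shown here, the only evidence to hand is the limit of > 63000 nM in this assay, at which 3 of the 3 values shown sit.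

The next compound, compound 4, `CCc1ccc(S(=O)(=O)Nc2ccc3oc(-c4ccccc4)nc3c2)cc1`, differs from compound 3 by ethyl in place of hydroxy on an aromatic carbon. Among the measured compounds shown here, no measured step bears on this change: no measured pair differs in this way, and the single measured step is unreadable. For the measured compounds named here, with every value so far sitting at the limit, there is no footing to expect a step of readable size in this assay, and the likeliest outcome is that compound 4 again returns only a limit. Compound 4 is therefore estimated at 63000 nM, with a range from 20000 nM to 200000 nM. This estimate means an expected step of a number no higher from compound 3 to compound 4 (the limit leaves the size open).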

Compound 4, half-maximal inhibitory concentration: > 63000 nM
Compound 4: no number, only a limit; the forecaster's own chance of this, stated with the estimate: 80%; the middle value sits exactly at the limit.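

Within the data shown here, compound 3 and compound 4 each returned only a limit of the assay rather than a number, so no step between them can be read: the limit of > 63000 nM in this assay, at which 4 of the 4 values shown sit. The compounds shown leave open whether any change to the groups on the sulfonyl sulfur or to the shared core would give a measurable number in this assay.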